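A few compounds are considered here, and "the series" means these few. Any claim that something is new, unique, unknown or untested is made for them only; others in the source may bear on it.

The study concerns a small set of compounds examined in a functional assay on HL-60 cells (Homo sapiens) for cytotoxicity, read by MTT assay, with a stated time of 48 h; a lower number here means a stronger inhibitor, a higher number a weaker inhibitor. Compound 1 `Fc1cccc(-c2nc(Nc3ccccc3)c3ccccc3n2)c1` is one of them. In this assay compound 1 reaches only the assay limit, reported as > 50000 nM. Compound 2 `Fc1ccc2nc(-c3ccccc3)nc(Nc3ccccc3)c2c1` is a second member. In this assay compound 2 likewise gives only a limit, > 50000 nM. The account follows compound 3 `Fc1cccc(-c2nc(Nc3ccc(Br)cc3)c3cc(F)ccc3n2)c1`. In this assay compound 3 also stands at a limit, > 50000 nM. Among the measured compounds shown here, all three results sit at the same place, as summarised by the limit of > 50000 nM in this assay, at which 3 of the 3 values shown sit, so no measurable step separates any pair of them. Compound 4 `Cc1ccc(Nc2nc(-c3cccc(F)c3)nc3ccc(F)cc23)cc1` has yet to be tested in this assay. It differs from compound 3 by methyl in place of bromo on an aromatic carbon. For the measured compounds named here, with no measured step available, the expectation rests only on the shared position of the three results. The step from compound 3 to compound 4 is expected to be a step that the limit leaves unreadable from compound 3 to compound 4, that is, nothing beyond the scatter in either direction. For compound 4 an inhibitory concentration of about 60000 nM is estimated, between 20000 nM and 200000 nM, with a good chance that this assay again reports only a limit.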

Compound 4, half-maximal inhibitory concentration: > 50000 nM
Compound 4: only a limit was reported; the forecaster's own chance of this, stated with the estimate: 75%; the middle value is on the limit's open side.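

In this assay compound 4 also gives only a limit, so no step can be read between compound 3 and compound 4, and the results stay together: the limit of > 50000 nM in this assay, at which 4 of the 4 values shown sit.

The compounds shown leave open what change to the shared core, if any, would bring a measurable inhibitory concentration.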